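Replacing a thiophene-methyl amine with a cyanobenzyl ether

The source may report more compounds than this note shows. Statements on the series, on what has been measured and on what is new or still open speak of the compounds shown alone.

In a functional assay on CHOK cells for antagonist activity at growth hormone secretagogue receptor type 1 (Homo sapiens), read by calcium flux (a lower number here means a stronger inhibitor, a higher number a weaker inhibitor), compound 1 `CCc1nc(N)nc(N)c1-c1ccc(NCc2ccc(S(C)(=O)=O)cc2)cc1` gives 12 nM, compound 2 `CCc1nc(N)nc(N)c1-c1ccc(NCc2ccc([N+](=O)[O-])cc2)cc1` gives 23 nM, and compound 3 `Nc1nc(N)c(-c2ccc(NCc3csc(Cl)c3)cc2)c(COCc2ccccc2)n1` gives 170 nM, the highest of the three numbers. Among the measured compounds shown here, the only single-point step among them, a 1.9-fold higher number from compound 1 to compound 2 (0.28 log units; within the scatter), exchanges one group on an aromatic carbon at the far end of the side chain. Compound 4 `N#Cc1ccc(COc2ccc(-c3c(N)nc(N)nc3COCc3ccccc3)cc2)cc1` differs from compound 3 by (4-cyanobenzyl)oxy in place of ((5-chlorothiophen-3-yl)methyl)amino on an aromatic carbon. For the measured compounds named here, no measured step alters the linking atom or exchanges a five-membered aromatic ring for a six-membered one, so the measured step offers only a loose guide; it shows that a change at the end of the side chain stayed within the scatter. A modest step in this assay is therefore expected, a 1.3-fold higher number from compound 3 to compound 4 (0.11 log units; within the scatter). Compound 4 is expected to give about 220 nM, between 60 nM and 900 nM.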

Compound 4, half-maximal inhibitory concentration: 3610 nM
For compound 4 the middle estimate is 16-fold (1.22 log units) below the measured one; measured number above the stated range.
By their numbers in this assay, from the lowest: compounds 1 and 2 (each within the scatter of the next); then compound 3; then compound 4.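

In this assay the exchange gives a 21-fold higher number from compound 3 to compound 4 (1.33 log units; beyond the scatter) and so shows that this position does not accept every large group on the aromatic carbon. The change is not a simple ring swap: the linking nitrogen gives way to oxygen, the hydrogen-bond donor is lost, and the five-membered aromatic ring becomes a six-membered one, all at once. The compounds shown cannot separate these changes, and a (4-cyanobenzyl)amino group on the same core would test the linking atom alone. Nothing available gives a reason for the large rise in the number.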